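Replacing the phenylsulfanyl chain with a chlorophenyl group

A few compounds are considered here, and "the series" means these few. Any claim that something is new, unique, unknown or untested is made for them only; others in the source may bear on it.

Compound 3 `Nc1nc(O)c2c(n1)n(C1OC(CO)[C@@H](O)[C@H]1O)c(=O)n2CC(O)CSc1ccccc1` was tested in a functional assay (B cells) with Mus musculus as the target (on this read-out higher numbers stand for an effect only at larger amounts of compound and lower numbers for an effect already at smaller amounts), where compound 3 gives 142 uM. Among the three compounds measured, compound 3 holds the second highest number. Compound 2 `CCCn1c(=O)n(C2CCC(COC(C)=O)O2)c2nc(NC(C)=O)nc(O)c21` gives 154 uM, a value within the scatter of compound 3. Among the compounds with values here, compound 1 `[N-]=[N+]=NCC(O)Cn1c(=O)n(C2OC(CO)[C@@H](O)[C@H]2O)c2nc(N)nc(O)c21` gives 39 uM, and the step of a 3.6-fold higher number from compound 1 to compound 3 (0.56 log units; beyond the scatter) is the only measured step between compounds that differ in one place.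

Compound 4 `Nc1nc(O)c2c(n1)n(C1OC(CO)[C@@H](O)[C@H]1O)c(=O)n2Cc1ccc(Cl)cc1` has not yet been measured in this assay. It differs from compound 3 by 4-chlorophenyl in place of 1-hydroxy-2-(phenylsulfanyl)ethyl on a saturated chain carbon bound to an aromatic nitrogen. Within the data shown here, the only measured step touching the group on this chain carbon is a 3.6-fold higher number from compound 1 to compound 3 (0.56 log units; beyond the scatter), a modest change. Among the measured compounds shown here, no measured pair swaps the whole hydroxy-bearing chain for an aryl group, so the direction of the coming step is uncertain. The estimated step is a 1.4-fold lower number from compound 3 to compound 4 (0.15 log units; within the scatter), expected to be modest. Compound 4 is therefore expected to give 100 uM in this assay, with a range from 30 uM to 300 uM.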

Compound 4, concentration for half-maximal effect: 14 uM
The estimate for compound 4 lay 7.1-fold (0.85 log units) above the measured number; the measured number lies below the stated range.
By their numbers in this assay, from the lowest: compound 4; then compound 1; then compounds 3 and 2 (each within the scatter of the next).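

In this assay, the hydroxy-bearing chain on this saturated chain carbon bound to an aromatic nitrogen turns out not to be needed for an effect at smaller amounts: 4-chlorophenyl in place of 1-hydroxy-2-(phenylsulfanyl)ethyl gives a 10-fold lower number from compound 3 to compound 4 (1.01 log units; beyond the scatter), and in place of 2-azido-1-hydroxyethyl it gives a 2.8-fold lower number from compound 1 to compound 4 (0.44 log units; beyond the scatter). The earlier step had changed only the end of the chain, whereas these steps show that a group with no hydrogen-bond donor or acceptor goes beyond both chain-bearing compounds. Nothing available explains why the number falls.

Each step changes the chain and the aryl group at once, so the share of the chlorine cannot be separated from that of the lost hydroxy. As far as these compounds go, it also remains open whether plain phenyl, or an amine or a carboxylic acid in place of the chlorine, would keep the number this low.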